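Geranyl-type flavonol series: losing the aromatic-carbon chain

The compounds below may be only part of what the source reports. "The series", "measured", "known", "first", "only" and "open" are said of these compounds alone.

Measured in a functional assay on HeLa cells (Homo sapiens) for cytotoxicity, read by XTT assay, with a stated time of 72 h; on this read-out lower numbers stand for stronger inhibition and higher numbers for weaker inhibition:
- compound 1 `C=C1CC[C@H]2C(C)(C)CCC[C@]2(C)[C@H]1CC/C(C)=C/Cc1c(O)cc(O)c2c(=O)c(O)c(-c3ccc(O)cc3)oc12`: 30000 nM
- compound 2 `CC(C)=CCC/C=C(\C)Cc1c(O)cc(O)c2c(=O)c(OC/C=C(\C)CCC=C(C)C)c(-c3ccc(O)cc3)oc12`: 27000 nM

Compound 2 at 27000 nM lies within the scatter of compound 1 at 30000 nM, so the two cannot be separated in this assay. Compound 3 `CC(C)=CCC/C(C)=C/COc1c(-c2ccc(O)cc2)oc2cc(O)cc(O)c2c1=O` follows from compound 2 by hydrogen in place of 2,7-dimethylocta-2,6-dien-1-yl on an aromatic carbon, para to a hydroxy group. Among the measured compounds shown here, both measured compounds carry a chain on that carbon and compound 3 does not, so no measured step covers this change. A small shift toward weaker inhibition is expected, possibly not beyond the scatter. The expected change is a 1.5-fold higher number from compound 2 to compound 3 (0.17 log units; within the scatter). For compound 3 the estimated value is 40000 nM, with an expected range of 14000 nM to 100000 nM.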

Compound 3, half-maximal inhibitory concentration: 23000 nM
Compound 3: middle estimate off by 1.7-fold (0.24 log units), on the high side, within the range that was stated.
By their numbers in this assay, from the lowest: compounds 3, 2 and 1 (each within the scatter of the next).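

In this assay, hydrogen in place of 2,7-dimethylocta-2,6-dien-1-yl on this aromatic carbon, para to a hydroxy group, gives a 1.2-fold lower number from compound 2 to compound 3 (0.07 log units; within the scatter). The read-out therefore does not separate compound 2 at 27000 nM from compound 3 at 23000 nM, and in this pair the 2,7-dimethylocta-2,6-dien-1-yl chain on this carbon is not needed to keep the number at this level. Nothing at hand accounts for this result or ties it to any property of the chain.

Still open, from the compounds shown here alone, is whether an amine, a carboxylic acid or a shorter chain such as 3-methylbut-2-enyl on this carbon would leave the number in the same range. Also open is what the chain retained by compound 3 contributes, since this step leaves that chain in place and the compounds shown offer no step that changes it alone.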